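Trading an Aryl Group for Ethyl on a Ring Nitrogen

This account rests on a few compounds, and the source may have more. Where it says the series, first, only, none or still open, it means among the compounds named here.

Of the compounds shown here, three have so far been tested in a functional assay on HOS-TE85 cells (Homo sapiens) for inhibition, read by CCK-8 assay, with a stated time of 72 h, tested at 1 uM; a higher number here means more inhibition at the concentration tested (going by the name of the read-out), a lower number less inhibition. Compound 1 `COc1ccccc1N1C(=O)C(C)SC1c1cccc(C(=O)NCCCCc2ccccc2)c1` gives 95% in this assay. Compound 3 `O=C(NCCCCc1ccccc1)c1cccc(C2OCC(=O)N2c2cccc(F)c2)c1` gives 87% in this assay. Compound 2 `COc1ccc(OC)c(N2C(=O)CSC2c2cccc(C(=O)NCCCCc3ccccc3)c2)c1` gives 20% in this assay, the lowest of the three readings, and its distance from each of the other two lies beyond the usual scatter of such measurements.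

Compound 4 `CCN1C(=O)CSC1c1cccc(C(=O)NCCCCc2ccccc2)c1` has not yet been measured. It differs from compound 2 in one place: ethyl in place of 2,5-dimethoxyphenyl on an amide-type nitrogen in a ring. For the measured compounds named here, no pair of measured compounds shows the effect of exactly this change, so any expectation rests on the spread of the three numbers alone. That spread shows that the group on the amide-type nitrogen in a ring matters a great deal, with compound 2 far below compound 1 and compound 3. Exchanging that group in compound 2 could therefore move the reading a long way, though the size is uncertain. The step from compound 2 to compound 4 is estimated at a number 30 percentage points higher from compound 2 to compound 4 (beyond the scatter), upward. Compound 4 is expected to give about 50% in this assay, within a range of 10% to 90%.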

Compound 4, a percentage reported as inhibition, at one concentration (the size of the read-out at that concentration, not a potency): 0%
The estimate for compound 4 lay 50 percentage points above the measured number, and the stated range ends above it.
By their numbers in this assay, from the lowest: compound 4; then compound 2; then compounds 3 and 1 (each within the scatter of the next).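

For the compounds shown here, putting ethyl in place of 2,5-dimethoxyphenyl on the amide-type nitrogen in a ring gives a change in this assay of a number 20 percentage points lower from compound 2 to compound 4 (beyond the scatter), the first direct comparison at this position. The low reading of compound 2 therefore does not simply come from carrying the 2,5-dimethoxyphenyl group, since removing it with the ethyl swap lowers the number further rather than restoring it. Nothing shown here explains this fall.

Open, on these data alone, is how an unsubstituted phenyl, a benzyl group, a cyclohexyl ring or a longer chain such as butyl would read on this same nitrogen. Also open, as far as these compounds go, is whether ethyl would lower the reading in the same way with the methyl-bearing ring of compound 1 or the ring of compound 3.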